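The source may hold more compounds than are shown below. What is called first, only, known or untested is meant among the compounds shown, and "the series" means these compounds.

For the measured compounds named here, compound 2 `Nc1ncnc(Oc2ccc(NC(=O)C3(C(=O)Nc4ccc(F)cc4)CC3)cc2F)c1/C=N/OCCCN1CCCC1` gives 3.82 in a physicochemical assay for lipophilicity, using the shake flask method (on this read-out higher numbers stand for higher lipophilicity and lower numbers for lower lipophilicity), the highest of the two numbers so far, with compound 1 `C=CCO/N=C/c1c(N)ncnc1Oc1ccc(NC(=O)C2(C(=O)Nc3ccc(F)cc3)CC2)cc1F` nearest at 3.65, a gap within the scatter. Compound 3 `Nc1ncnc(Oc2ccc(NC(=O)C3(C(=O)Nc4ccc(F)cc4)CC3)cc2F)c1/C=N/OCC(=O)N1CCOCC1` carries the change ((morpholin-4-yl)carbonyl in place of 2-(pyrrolidin-1-yl)ethyl on a saturated chain carbon bound to an oxygen). Going by the values given here, the only step at that place, a number 0.17 log units higher from compound 1 to compound 2 (within the scatter), was within the scatter, but no measured step covers an entering group of this kind, so the expectation rests on compound 2 with a wide range. Compound 3 is estimated to show a number 0.42 log units lower from compound 2 to compound 3 (beyond the scatter), giving an expected 3.4 between 2.8 and 4.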

Compound 3, partition coefficient: 2.1
Estimate against measurement, compound 3: 1.30 log units above; the measured number lies below the stated range.
By their numbers in this assay, from the lowest: compound 3; then compounds 1 and 2 (each within the scatter of the next).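

At this place, on a saturated chain carbon bound to an oxygen, the change can move the read-out in this assay far: a number 1.72 log units lower from compound 2 to compound 3 (beyond the scatter), and a number 1.55 log units lower from compound 1 to compound 3 (beyond the scatter). The entering (morpholin-4-yl)carbonyl therefore sets compound 3 clearly apart, whereas the two earlier groups stayed within the scatter of each other. Nothing available bears on why the number fell so far.

Still open, from the compounds shown here alone, is whether the carbonyl or the morpholine ring carries this step, which a 2-(morpholin-4-yl)ethyl chain or a (pyrrolidin-1-yl)carbonyl group at this place would separate.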